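A trifluoromethoxy swap on compound 1

The source may hold more compounds than are shown below. What is called first, only, known or untested is meant among the compounds shown, and "the series" means these compounds.

Compound 1 `OC[C@H]1O[C@@H](n2cnc3c(NCc4cccc(F)c4)ncnc32)[C@H](O)[C@@H]1O`: 7600 nM
Compound 2 `Cc1cccc(CNc2ncnc3c2ncn3[C@@H]2O[C@H](CO)[C@@H](O)[C@H]2O)c1O`: 18000 nM

Within the data shown here, in a functional assay on K562 cells (Homo sapiens) for antiproliferative activity, with a stated time of 72 h (a higher number here means a weaker inhibitor, a lower number a stronger inhibitor), compound 1 gives 7600 nM, the lower of the two numbers so far. Compound 3 `OC[C@H]1O[C@@H](n2cnc3c(NCc4cccc(OC(F)(F)F)c4)ncnc32)[C@H](O)[C@@H]1O` carries trifluoromethoxy in place of fluoro on an aromatic carbon. Among the measured compounds shown here, the one measured step that bears on this is a 2.4-fold higher number from compound 1 to compound 2 (0.37 log units; beyond the scatter), a modest change at the same aromatic group. That single step does not show which direction the new group should take, so no clear shift beyond the scatter is expected. The expected step is a 1.1-fold lower number from compound 1 to compound 3 (0.04 log units; within the scatter). The estimated value for compound 3 is 7000 nM, with an expected range of 2500 nM to 20000 nM.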

Compound 3, half-maximal inhibitory concentration: > 166000 nM
Compound 3: no number, only a limit; the forecaster's own chance of this, stated with the estimate: 8%; at least 23-fold (1.37 log units) between middle value and limit.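

In this assay, compound 3 gives no number, only a limit: > 166000 nM. Trifluoromethoxy in place of fluoro gives an at least 21-fold higher number from compound 1 to compound 3 (1.33 log units; beyond the scatter), whereas the earlier change on this aromatic group gave a 2.4-fold higher number from compound 1 to compound 2 (0.37 log units; beyond the scatter), so this aromatic carbon does not accept every group alike. Compound 3 is the only compound shown that ends at a limit of the assay: the limit of > 166000 nM in this assay, at which 1 of the 3 values shown sits.

From the compounds shown here alone, whether a methoxy or a trifluoromethyl group on the same aromatic carbon would track with fluoro or with trifluoromethoxy stays open. The limit also leaves the true size of the step unknown.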